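A few compounds are considered here, and "the series" means these few. Any claim that something is new, unique, unknown or untested is made for them only; others in the source may bear on it.

Compound 1 `CCCCCCCCCCn1cc(/C=C/C(=O)c2ccc(NC(=O)CN3CCN(C(=O)OC(C)(C)C)CC3)cc2)nn1` and compound 2 `CCCCCCCCCCn1cc(/C=C/C(=O)c2ccc(NC(=O)CN3CCN(c4ccc([N+](=O)[O-])cc4)CC3)cc2)nn1` share one core and differ only in the group on the amine nitrogen in the ring. In a functional assay on MCF7 cells (Homo sapiens) for inhibition, read by MTT assay (on this read-out lower numbers stand for stronger inhibition and higher numbers for weaker inhibition), compound 1 gives 40000 nM, and compound 2 gives 44400 nM. The step of a 1.1-fold higher number from compound 1 to compound 2 (0.05 log units; within the scatter) lies within the scatter. Of the two numbers, compound 2 reads as the higher, yet the gap to compound 1 is within the scatter, so the two cannot be placed apart. Compound 3 `CCCCCCCCCCn1cc(/C=C/C(=O)c2ccc(NC(=O)CN3CCN(c4ccccc4F)CC3)cc2)nn1` has not yet been measured. It differs from compound 2 by 2-fluorophenyl in place of 4-nitrophenyl on an amine nitrogen in a ring. Among the compounds with values here, the only measured step that bears on this change is the one at the same position, a 1.1-fold higher number from compound 1 to compound 2 (0.05 log units; within the scatter), which stayed within the scatter. No step beyond the scatter is known at this site, so no shift beyond the scatter is expected in this assay. For compound 3 a value of 40000 nM is estimated, with a range from 15000 nM to 110000 nM. The expected step is a 1.1-fold lower number from compound 2 to compound 3 (0.05 log units; within the scatter).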

Compound 3, half-maximal inhibitory concentration: 40400 nM
For compound 3 the middle estimate is 1.0-fold (0.00 log units) below the measured one; low and high end bracket the measured number.
By their numbers in this assay, from the lowest: compounds 1, 3 and 2 (each within the scatter of the next).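

Replacing 4-nitrophenyl with 2-fluorophenyl gives a 1.1-fold lower number from compound 2 to compound 3 (0.04 log units; within the scatter), and replacing tert-butoxycarbonyl with 2-fluorophenyl gives a 1.0-fold higher number from compound 1 to compound 3 (0.00 log units; within the scatter); both steps lie within the scatter. The earlier pair rested on a single change, whereas here a third group at this amine nitrogen, with 0 hydrogen-bond acceptors where 4-nitrophenyl has 2, also cannot be told apart from the others in this assay, so the three compounds cannot be placed apart. Nothing available explains why these numbers stay together.

As far as these compounds go, whether an acetyl group, a free amine or a carboxylic acid at this nitrogen would give a step beyond the scatter remains open. So does whether a shorter chain in place of the long chain on the shared core would move the number at all.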